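Swapping the spiro amine of compound 1 for methylpiperazine

The source may hold more compounds than are shown below. What is called first, only, known or untested is meant among the compounds shown, and "the series" means these compounds.

Measured compounds:
- compound 1, `CN1CC2(C1)CN(c1ccc(OCc3ccccc3)c(C(=O)Nc3ccnnc3)c1)C2`: 2
- compound 2, `CN1CCC(c2ccc(OCc3ccccc3)c(C(=O)Nc3ccnnc3)c2)CC1`: 2.3
- compound 3, `O=C(Nc1ccnnc1)c1cc(N2CCC(CO)CC2)ccc1OCc1ccccc1`: 3.5

In a physicochemical assay for lipophilicity, at pH 7.4 (on this read-out lower numbers stand for lower lipophilicity and higher numbers for higher lipophilicity), compound 1 stands lowest of the three. Its step to compound 2 is small, a number 0.30 log units higher from compound 1 to compound 2 (within the scatter), while the step to compound 3 is large, a number 1.50 log units higher from compound 1 to compound 3 (beyond the scatter). Compound 4, `CN1CCN(c2ccc(OCc3ccccc3)c(C(=O)Nc3ccnnc3)c2)CC1`, is not yet measured. It differs from compound 1 in one place: a group of 7 heavy atoms (5 carbon, 2 nitrogen; one six-membered non-aromatic ring with 2 hetero atoms) in place of a group of 8 heavy atoms (6 carbon, 2 nitrogen; 2 four-membered non-aromatic rings with 1 hetero atom each), on an aromatic carbon. The step from compound 1 to compound 2 also kept a methyl-bearing nitrogen and stayed within the scatter, so a comparable outcome is expected here, with no step beyond the scatter: a number 0.20 log units higher from compound 1 to compound 4 (within the scatter). Compound 4 is thus estimated at 2.2, between 1.6 and 2.8.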

Compound 4, distribution coefficient: 3
The estimate for compound 4 lay 0.80 log units below the measured number; measured number above the stated range.
By their numbers in this assay, from the lowest: compounds 1 and 2 (each within the scatter of the next); then compound 4; then compound 3.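

In this assay, the choice of six-membered ring at this position, para to a benzyloxy group, matters more than compound 2 suggested: a number 1.00 log units higher from compound 1 to compound 4 (beyond the scatter), and a number 0.70 log units higher from compound 2 to compound 4 (beyond the scatter). Both rings carry a methyl on nitrogen, yet they differ in how they attach, through ring nitrogen in 4-methylpiperazin-1-yl and through ring carbon in 1-methylpiperidin-4-yl. Exchanging the hydroxymethyl piperidine gives a number 0.50 log units lower from compound 3 to compound 4 (beyond the scatter). Nothing measured here explains these gaps. From the compounds shown here alone, whether morpholin-4-yl, with a ring oxygen in place of the methyl-bearing nitrogen, would stand nearer compound 1 or compound 4 stays open.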